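The source may report more compounds than this note shows. Statements on the series, on what has been measured and on what is new or still open speak of the compounds shown alone.

The measured compounds in a functional assay on the whole organism for inhibition, with Rattus norvegicus as the target, at a dose of 50 mg/kg by the oral route; a higher number here means more inhibition at the dose given (going by the name of the read-out), a lower number less inhibition:

compound 1, `CCOC(=O)c1c(CSc2nncn2C)nc2cc(OC)c(OC)cc2c1-c1ccc(OC)c(OC)c1`, 66%
compound 2, `CCOC(=O)c1c(CSc2nccn2CC)nc2cc(OC)c(OC)cc2c1-c1ccc(OC)c(OC)c1`, 51%
compound 3, `CCOC(=O)c1c(CSc2nccn2C)nc2cc(OC)c(OC)cc2c1-c1ccc(OC)cc1`, 64%

Compound 3 stands second highest of the three numbers in this assay. Compound 1 gives 66%, a gap within the usual scatter, so the two cannot be ordered. Compound 2 gives 51%, which lies beyond the scatter below compound 3. Going by the values given here, the one measured single-place step, a number 15 percentage points lower from compound 1 to compound 2 (beyond the scatter), changes the group on the sulfur, not the aryl ring.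

Compound 4, `CCOC(=O)c1c(CSc2nccn2C)nc2cc(OC)c(OC)cc2c1-c1ccc(Cl)cc1`, differs from compound 3 at that aryl ring: chloro in place of methoxy on an aromatic carbon. Among the compounds with values here, no measured step alters this ring alone. Compounds 1 and 3 differ both there and on the sulfur, and their values fall within the scatter of each other, which gives no pointer for the para substituent in either direction. The expected step of a number 6 percentage points lower from compound 3 to compound 4 (within the scatter) is therefore none beyond the scatter, with a wide range around it. Compound 4 is estimated at 58%, between 40% and 76%.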

Compound 4, a percentage reported as inhibition, in the whole organism at one dose (the size of the read-out at that dose, not a potency): 41%
Compound 4: middle estimate off by 17 percentage points, on the high side; the measured number falls inside the stated range.
By their numbers in this assay, from the lowest: compounds 4 and 2 (each within the scatter of the next); then compounds 3 and 1 (each within the scatter of the next).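

The aryl ring, untouched by the earlier single-place step, now has a measured step of its own: in this assay, chloro in place of methoxy gives a number 23 percentage points lower from compound 3 to compound 4 (beyond the scatter). The group on this aromatic carbon, para to a large group, therefore matters to the inhibition seen at this dose, and swapping 4-methoxyphenyl for 4-chlorophenyl is not a neutral exchange here. Nothing available explains this step.

With only these two groups shown at this place, the compounds leave open whether the lower number reflects the loss of methoxy or the arrival of chloro. They also leave open how an amine, a hydroxyl, a fluoro or a longer chain such as ethoxy would read at the same carbon.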